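Two Stereocentres Changed in a Cytotoxic Compound

The source may hold more compounds than are shown below. What is called first, only, known or untested is meant among the compounds shown, and "the series" means these compounds.

Measured so far:
Compound 1 `CCCCC[C@H](C[C@@H](O)C[C@H]1CC=CC(=O)O1)OC` at 18100 nM
Compound 2 `CCCCC[C@@H](CCC[C@@H]1CC=CC(=O)O1)OC` at 11500 nM

Both numbers come from a functional assay on A2780 ADR cells (Homo sapiens) for cytotoxicity, read by MTT assay, with a stated time of 24 h (on this read-out lower numbers stand for stronger inhibition and higher numbers for weaker inhibition), and lie within the usual scatter of each other, so compound 1 stands level with compound 2 on this evidence. The next candidate is compound 3 `CCCCC[C@H](C[C@H](O)C[C@@H]1CC=CC(=O)O1)OC`, which has not been measured. Its difference from compound 1 is the two compounds have the same atoms and bonds and differ only in configuration as drawn: 2 of 3 stereo elements differ; a stereocentre at a saturated chain carbon is drawn R in compound 1 and S in compound 3; a stereocentre at a saturated ring carbon is drawn R in compound 1 and S in compound 3 and nothing else: the two compounds have the same atoms and bonds and differ only in configuration as drawn. Going by the values given here, no measured pair isolates such a change, so the data give no direction for it in this assay and no step beyond the scatter is expected. The estimate means a 1.2-fold lower number from compound 1 to compound 3 (0.08 log units; within the scatter) as the expected step. Compound 3 is expected at about 15000 nM in this test. The estimated range runs from 6000 nM to 35000 nM and is kept wide for lack of a direct precedent.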

Compound 3, half-maximal inhibitory concentration: 30000 nM
The estimate for compound 3 lay 2.0-fold (0.30 log units) below the measured number; the range from low to high includes it.
By their numbers in this assay, from the lowest: compounds 2, 1 and 3 (each within the scatter of the next, the first and the last beyond it).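

In this assay, the pair gives a 1.7-fold higher number from compound 1 to compound 3 (0.22 log units; within the scatter) as the first direct reading of a change in configuration among these compounds. This comparison speaks to configuration alone, because nothing else separates the two compounds: the fact that compounds 1 and 3 differ only in the configuration as drawn. Inverting the saturated chain carbon and the saturated ring carbon together therefore leaves the two numbers level, so this pair gives no sign that the drawn configuration at these two stereocentres matters in this test.

The compounds shown do not separate the chain stereocentre from the ring stereocentre, so a change at one alone, or two opposing effects that cancel, remains possible. They also leave open how this assay would respond to an amine or a carboxylic acid on the shared core.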